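A few compounds are considered here, and "the series" means these few. Any claim that something is new, unique, unknown or untested is made for them only; others in the source may bear on it.

Compound 1 `CC(OC(=O)N1CCN(C(=O)c2nc(Nc3cc(C4CC4)[nH]n3)c3cc(Cl)ccc3n2)C[C@H]1C)OC(=O)C(C)(C)C`: 66.3%
Compound 2 `CC(OC(=O)C(C)C)OC(=O)N1CCN(C(=O)c2nc(Nc3cc(C4CC4)[nH]n3)c3cc(Cl)ccc3n2)C[C@H]1C`: 11%
Compound 3 `C[C@@H]1CN(C(=O)c2nc(Nc3cc(C4CC4)[nH]n3)c3cc(Cl)ccc3n2)CCN1C(=O)OCC(Cl)(Cl)Cl`: 78.9%

In an ADME assay on S9 fraction from liver (Rattus norvegicus), read by LC-MS, with a stated time of 60 min, at 37 degrees C (on this read-out lower numbers stand for a less stable compound and higher numbers for a more stable compound), compound 1 stands second highest of the three measured numbers; compound 3 lies above it by a number 12.6 percentage points higher from compound 1 to compound 3 (beyond the scatter), and compound 2 lies below it by a number 55.3 percentage points lower from compound 1 to compound 2 (beyond the scatter). Compound 4 `C[C@@H]1CN(C(=O)c2nc(Nc3cc(C4CC4)[nH]n3)c3cc(Cl)ccc3n2)CCN1C(=O)OCOC(=O)C(C)(C)C` differs from compound 1 by hydrogen in place of methyl on a saturated chain carbon bound to two oxygens next to a carbonyl group. Among the measured compounds shown here, no measured step makes exactly this change. The closest guide is a number 55.3 percentage points lower from compound 1 to compound 2 (beyond the scatter), where a methyl is likewise replaced by hydrogen, though on another carbon of the same side group; the step of a number 12.6 percentage points higher from compound 1 to compound 3 (beyond the scatter) exchanges the whole side group and bears less on this question. A downward step of moderate size is therefore expected in this assay, with wide uncertainty. Compound 4 is estimated at 42%, in the range 15% to 70%, an expected step of a number 24.3 percentage points lower from compound 1 to compound 4 (beyond the scatter).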

Compound 4, percent of the compound remaining: 47%
The estimate for compound 4 lay 5 percentage points below the measured number; measured number inside the range.
By their numbers in this assay, from the lowest: compound 2; then compound 4; then compound 1; then compound 3.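

In this assay, hydrogen in place of methyl on the saturated chain carbon bound to two oxygens next to a carbonyl group gives a number 19.3 percentage points lower from compound 1 to compound 4 (beyond the scatter) and shows that this carbon also bears on the read-out. The (((tert-butyl)carbonyl)oxy)methyl side group places compound 4 between the other two, with a number 36 percentage points higher from compound 2 to compound 4 (beyond the scatter) on one side and a number 31.9 percentage points lower from compound 3 to compound 4 (beyond the scatter) on the other. No measurement at hand explains these shifts. On these data alone, whether an ethyl group or a longer chain on that carbon would raise or lower the number remains open. So does whether the same change would act alike with the isopropylcarbonyl group of compound 2.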